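A few compounds are considered here, and "the series" means these few. Any claim that something is new, unique, unknown or untested is made for them only; others in the source may bear on it.

Measured so far:
- compound 1, `CC(C)CC/N=C(\NC#N)Nc1cccnc1`: 20 mg/kg
- compound 2, `CC(C)(C)C/N=C(/NC#N)Nc1cccnc1`: 2.5 mg/kg

In a functional assay on the whole organism (blood, strain Wistar-Okamoto) with Rattus norvegicus as the target, with a stated time of 5 days (a higher number here means that more compound is needed for the effect, a lower number that less compound is needed), compound 1 gives 20 mg/kg, the higher of the two numbers measured. Compound 2 gives 2.5 mg/kg, a lower number, and the gap between the two lies beyond the scatter. Compound 3, `N#CN/C(=N\CC1CCCO1)Nc1cccnc1`, has not been measured. It differs from compound 1 in one place: oxolan-2-yl in place of isobutyl on a saturated chain carbon bound to a double-bonded nitrogen. Among the measured compounds shown here, no pair of measured compounds shows this change, so the size of its step is unknown. Compound 3 is expected to need somewhat less compound, a step of a 1.7-fold lower number from compound 1 to compound 3 (0.22 log units; within the scatter) that may not clear the scatter. Compound 3 is therefore estimated at 12 mg/kg, within 4 mg/kg to 40 mg/kg.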

Compound 3, minimum effective dose: 50 mg/kg
Compound 3: the middle estimate sits 4.2-fold (0.62 log units) below what was measured; the measured number lies above the stated range.
By their numbers in this assay, from the lowest: compound 2; then compound 1; then compound 3.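

In this assay, oxolan-2-yl in place of isobutyl on a saturated chain carbon bound to a double-bonded nitrogen gives a 2.5-fold higher number from compound 1 to compound 3 (0.40 log units; beyond the scatter), a modest step but one beyond the scatter. This shows that the number responds to a change at this position, and that this change raises the dose needed rather than lowering it. No available evidence bears on why the number rises.

As far as these compounds go, whether the step follows the ring or its oxygen stays open, and a cyclopentyl group in the same place would separate the two.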